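Swapping a Phenol Ring for a Hydroxypyridine Ring

The source may report more compounds than this note shows. Statements on the series, on what has been measured and on what is new or still open speak of the compounds shown alone.

Compound 1 `Cc1cccc(NC(=O)CN2CCC(c3ccc(O)cc3)CC2)c1` holds the lower of the two numbers recorded so far: in a functional assay on HEK293 cells for agonist activity at D(4) dopamine receptor (Homo sapiens), read by FLIPR (on this read-out lower numbers stand for an effect already at smaller amounts and higher numbers for an effect only at larger amounts of compound), compound 1 gives 70 nM. Compound 2 `COc1cc(C(=O)NCN2CCC(c3cccc[n+]3[O-])CC2)ccc1Cl`, built quite differently, gives 159 nM in this assay, a gap that lies beyond the usual scatter. Compound 3 `Cc1cccc(NC(=O)CN2CCC(c3ccc(O)cn3)CC2)c1` has not yet been measured. It differs from compound 1 in a single place: 5-hydroxypyridin-2-yl in place of 4-hydroxyphenyl on a saturated ring carbon. Going by the values given here, no measured pair shows this kind of exchange, so its effect must be estimated. A modest weakening is expected, with the step of a 2.1-fold higher number from compound 1 to compound 3 (0.33 log units; beyond the scatter) judged to lie only a little beyond the scatter. Compound 3 is therefore expected to give about 150 nM in this assay, somewhere between 45 nM and 550 nM.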

Compound 3, half-maximal effective concentration: 3.8 nM
For compound 3 the middle estimate is 39-fold (1.60 log units) above the measured one; the measured number lies below the stated range.
By their numbers in this assay, from the lowest: compound 3; then compound 1; then compound 2.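

Exchanging one ring carbon for a nitrogen in the aromatic group is far from a neutral swap: in this assay, 5-hydroxypyridin-2-yl in place of 4-hydroxyphenyl gives an 18-fold lower number from compound 1 to compound 3 (1.27 log units; beyond the scatter). This first measured pair at this position shows that the number responds strongly here, although the group keeps the same count of heavy atoms. No measurement shown accounts for the size of this step.

Going by these compounds, it remains open whether the hydroxy group is needed on the new ring, and whether an amine or a carboxylic acid in its place would keep so low a number.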